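The source may report more compounds than this note shows. Statements on the series, on what has been measured and on what is new or still open speak of the compounds shown alone.

Measured compounds in this series:

compound 1, `CN(C(=O)CCc1ccccc1)c1ccc2[nH]c(-c3n[nH]c4ccccc34)cc2n1`, 11200 nM in a functional assay on HCT-116 cells (Homo sapiens) for antiproliferative activity, read by MTT assay, with a stated time of 72 h; a higher number here means a weaker inhibitor, a lower number a stronger inhibitor
compound 2, `CN(c1ccc2[nH]c(-c3n[nH]c4ccccc34)cc2n1)S(=O)(=O)c1ccc(Cl)cc1`, 5980 nM in this assay

Within the data shown here, compound 2 and compound 1 are the only two measured members, and they sit within the scatter of each other: a 1.9-fold lower number from compound 1 to compound 2 (0.27 log units; within the scatter). Among the measured compounds shown here, compound 2 therefore has no separate standing against compound 1 on the numbers so far.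

Compound 3, `COc1ccc(S(=O)(=O)N(C)c2ccc3[nH]c(-c4n[nH]c5ccccc45)cc3n2)cc1OC`, carries the change (3,4-dimethoxyphenyl in place of 4-chlorophenyl on a sulfonyl sulfur). For the measured compounds named here, the one measured step, a 1.9-fold lower number from compound 1 to compound 2 (0.27 log units; within the scatter), concerns a different part of the molecule, the exchange of the whole group on the aromatic nitrogen, and did not reach beyond the scatter. Going by the values given here, no measured step bears directly on swapping the aryl group on the sulfonyl sulfur, so there is nothing in the data to support a step beyond the scatter in either direction for compound 3 in this assay.

The step from compound 2 is expected to be a 1.1-fold lower number from compound 2 to compound 3 (0.04 log units; within the scatter), that is, none beyond the scatter. For compound 3 the estimated value in this assay is 5500 nM, with an expected range from 2000 nM to 16000 nM.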

Compound 3, half-maximal inhibitory concentration: 16700 nM
Estimate against measurement, compound 3: 3.0-fold (0.48 log units) below, and the stated range ends below it.
By their numbers in this assay, from the lowest: compounds 2, 1 and 3 (each within the scatter of the next, the first and the last beyond it).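

In this assay, among these compounds, the aryl group on the sulfonyl sulfur is the first place where a single exchange goes beyond the scatter, with a 2.8-fold higher number from compound 2 to compound 3 (0.45 log units; beyond the scatter) on 3,4-dimethoxyphenyl in place of 4-chlorophenyl. This place is therefore not indifferent to the aryl group it carries, and 4-chlorophenyl gives the lower number of the pair, although the step is modest and rests on that one pair alone. No measurement at hand accounts for the step.

On these data alone, it remains open whether the step follows from the loss of the chlorine, from the two methoxy groups together or from only one of them, which unsubstituted phenyl, 4-methoxyphenyl and 3-methoxyphenyl on the same sulfonyl sulfur would help to separate. Also open, as far as these compounds go, is how far the number can move in the lower direction at this place, for instance with 3,4-dichlorophenyl or 4-bromophenyl, and whether an amine or a carboxylic acid on the aryl ring is accepted at all.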